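Cytotoxicity on Mouse Fibroblasts: Swapping an Aryl Group for a Chain

The compounds below may be only part of what the source reports. "The series", "measured", "known", "first", "only" and "open" are said of these compounds alone.

Measured compounds:
compound 1, `O=C(c1ccn(-c2ccc3c(c2)B(O)OC3)c1)c1ccc(Cl)cc1Cl`, > 10 ug/mL
compound 2, `O=C(CCCN1C(=O)c2ccccc2C1=O)c1ccn(-c2ccc3c(c2)B(O)OC3)c1`, > 10 ug/mL

Both compounds share a core carrying a cyclic boronic acid, and both were tested in an ADME assay on L929 cells (Mus musculus) for cytotoxicity, read by resazurin assay, with a stated time of 72 h; a higher number here means a weaker inhibitor, a lower number a stronger inhibitor. In this assay compound 1 gives > 10 ug/mL, which is a limit of the assay rather than a number. Compound 2 likewise gives > 10 ug/mL in this assay, again only a limit. Where compound 1 stands can therefore be said only loosely: its result sits at the limit of > 10 ug/mL in this assay, at which 2 of the 2 values shown sit, and no finer number places it.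

Compound 3, `NCCCC(=O)c1ccn(-c2ccc3c(c2)B(O)OC3)c1`, has not yet been measured in this assay. It differs from compound 1 in one place: 3-aminopropyl in place of 2,4-dichlorophenyl on a carbonyl carbon. Among the compounds with values here, no step between measured compounds is available to guide the expectation, so the direction of change is open. Given that the two measured results both sit at the limit, the expected step that the limit leaves unreadable from compound 1 to compound 3 is small, with no direction beyond the scatter. The estimate for compound 3 in this assay is 20 ug/mL, within a range from 8 ug/mL to 60 ug/mL, and most likely the assay will again report only a limit.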

Compound 3, half-maximal inhibitory concentration: > 10 ug/mL
Compound 3 ended at the assay's limit; the forecaster's own chance of this, stated with the estimate: 85%; the middle value is on the limit's open side.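

In this assay compound 3 gives > 10 ug/mL, which is a limit of the assay and not a number. Within the data shown here, compound 1 is also known only as a limit, so no step from compound 1 to compound 3 can be read. Going by these compounds, what remains open is the actual value of each compound, and so whether 3-aminopropyl in place of 2,4-dichlorophenyl changes cytotoxicity at all.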